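Amide nitrogen substituents on a shared core: paw edema series

The compounds below may be only part of what the source reports. "The series", "measured", "known", "first", "only" and "open" are said of these compounds alone.

Measured compounds:
Compound 1, `COc1cc2c(cc1OC)C(CC(N)=O)CC2`, gives 30.4% in a functional assay on the whole organism (strain Wistar) for inhibition, with Rattus norvegicus as the target, read by paw edema, with stated times of 60 min and 3 h, at a dose of 100 mg/kg by the oral route; a higher number here means more inhibition at the dose given (going by the name of the read-out), a lower number less inhibition.
Compound 2, `CCNC(=O)CC1CCc2cc(OC)c(OC)cc21`, gives 26.1%.
Compound 3, `COc1cc2c(cc1OC)C(CC(=O)NC(C)(C)C)CC2`, gives 33.3%.

All three share one core and differ only in what sits on the amide-type nitrogen. On the bare numbers compound 2 sits at the bottom of the three, but the steps that separate it from the others, a number 4.3 percentage points lower from compound 1 to compound 2 (within the scatter) and a number 7.2 percentage points higher from compound 2 to compound 3 (within the scatter), both lie within the scatter, so the three are not distinguished from each other. The same holds for a number 2.9 percentage points higher from compound 1 to compound 3 (within the scatter).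

Compound 4, `COc1cc2c(cc1OC)C(CC(=O)NCc1ccccc1)CC2`, differs from compound 2 by phenyl in place of methyl on a saturated chain carbon bound to an amide-type nitrogen; cut one bond further out this reads ethyl to benzyl on the amide-type nitrogen.

Going by the values given here, the steps that bear on this change are those that alter the amide nitrogen substituent: hydrogen to ethyl, hydrogen to tert-butyl, and ethyl to tert-butyl. None of them moved the read-out beyond the scatter, and the nearest analogue, ethyl to tert-butyl, is the step given as a number 7.2 percentage points higher from compound 2 to compound 3 (within the scatter). No change beyond the scatter is therefore expected, and the step of a number 3.9 percentage points higher from compound 2 to compound 4 (within the scatter) is an estimate of that kind.

Compound 4 is expected to give about 30%, within a range of 16% to 44%.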

Compound 4, a percentage reported as inhibition, in the whole organism at one dose (the size of the read-out at that dose, not a potency): 14.5%
For compound 4 the middle estimate is 15.5 percentage points above the measured one; measured number outside the range, below it.
By their numbers in this assay, from the lowest: compound 4; then compounds 2, 1 and 3 (each within the scatter of the next).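

Going by these compounds alone, the amide nitrogen does not treat all its substituents alike in this assay: benzyl stands apart from ethyl with a number 11.6 percentage points lower from compound 2 to compound 4 (beyond the scatter) and from tert-butyl with a number 18.8 percentage points lower from compound 3 to compound 4 (beyond the scatter) and from the bare amide hydrogen with a number 15.9 percentage points lower from compound 1 to compound 4 (beyond the scatter) and these are the first steps to pass the scatter. Among the four compounds, the only one separated from the others is compound 4, the one in which phenyl enters on the saturated chain carbon bound to the amide-type nitrogen, while hydrogen, ethyl and tert-butyl remain within the scatter of one another, though a single benzyl example gives no general rule. Nothing available accounts for the lower inhibition seen with benzyl.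

Still open, going by these compounds, is whether the step belongs to the phenyl ring itself or to how it is attached, which phenyl directly on the amide nitrogen, a phenethyl chain or a cyclohexylmethyl group could help to separate. Also open, on these data alone, is whether a pyridylmethyl group or a methoxy-bearing benzyl would behave like benzyl, and all these readings describe one dose only, so they give sizes of inhibition and not potencies.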